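Pyrazolopyrimidine vinyl series: isopropylamino versus (4-fluorobenzyl)amino

The source may report more compounds than this note shows. Statements on the series, on what has been measured and on what is new or still open speak of the compounds shown alone.

Measured compounds:
- compound 1 `CCCc1nn(C)c2c(NC(C)C)nc(/C=C/c3nc(C)c(C)nc3C)nc12` gives 342000 nM
- compound 2 `CCCc1nn(C)c2c(NCc3ccc(F)cc3)nc(/C=C/c3nc(C)c(C)nc3C)nc12` gives a limit, > 1000000 nM
- compound 3 `CCCc1nn(C)c2c(NC(C)C)nc(/C=C/c3ccc[n+]([O-])c3)nc12` gives 324000 nM

All three were run in a functional assay on L02 cells (Homo sapiens) for inhibition, read by Griess assay, with stated times of 1 h and 24 h; a higher number here means a weaker inhibitor, a lower number a stronger inhibitor. Compound 1 gives 342000 nM there. For compound 2 the result is a limit of the assay rather than a number, > 1000000 nM. Compound 3 gives 324000 nM in this assay.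

The change from compound 1 to compound 2 is 4-fluorobenzyl in place of isopropyl on a nitrogen on an aromatic ring; it produced an at least 2.9-fold higher number from compound 1 to compound 2 (0.46 log units; beyond the scatter). The size of that step can only be given as a bound, because of the limit of > 1000000 nM in this assay, at which 1 of the 3 values shown sits.

The cores of compound 1 and compound 3 differ by a group of 7 heavy atoms (5 carbon, 1 nitrogen, 1 oxygen; one six-membered aromatic ring with 1 hetero atom) in place of a group of 9 heavy atoms (7 carbon, 2 nitrogen; one six-membered aromatic ring with 2 hetero atoms), on a double-bonded chain carbon bound to a double-bonded chain carbon. That exchange gave a 1.1-fold lower number from compound 1 to compound 3 (0.02 log units; within the scatter), so the two cores sit together in this assay.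

Compound 4 `CCCc1nn(C)c2c(NCc3ccc(F)cc3)nc(/C=C/c3ccc[n+]([O-])c3)nc12` is not yet measured. It differs from compound 3 by 4-fluorobenzyl in place of isopropyl on a nitrogen on an aromatic ring, which is the same change as that from compound 1 to compound 2, at the same place. Since the two cores behaved alike in the step from compound 1 to compound 3, the same change is expected to act on compound 3 much as it did on compound 1, giving an estimated 3.4-fold higher number from compound 3 to compound 4 (0.53 log units; beyond the scatter) in this assay. Compound 4 is therefore expected to give about 1100000 nM, with a range from 600000 nM to 3000000 nM, and a limit rather than a number is a likely outcome.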

Compound 4, half-maximal inhibitory concentration: < 40000 nM
Compound 4: a limit, no number; the forecaster's own chance of this, stated with the estimate: 65%; middle value at least 27-fold (1.43 log units) away from the limit.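

In this assay, 4-fluorobenzyl in place of isopropyl on the core of compound 3 gives an at least 8.1-fold lower number from compound 3 to compound 4 (0.90 log units; beyond the scatter), so this change does not carry over from the core of compound 1 to the core of compound 3: the same change on two cores in this assay, an at least 2.9-fold higher number (0.46 log units; beyond the scatter) from compound 1 to compound 2 and an at least 8.1-fold lower number (0.90 log units; beyond the scatter) from compound 3 to compound 4, at least 23-fold (1.37 log units) apart, beyond the scatter of two such steps. Seen from the other side, exchanging the two cores gives no step beyond the scatter with isopropylamino present, but with (4-fluorobenzyl)amino present it gives an at least 25-fold lower number from compound 2 to compound 4 (1.39 log units; beyond the scatter): the same change on two cores in this assay, a 1.1-fold lower number (0.02 log units; within the scatter) from compound 1 to compound 3 and an at least 25-fold lower number (1.39 log units; beyond the scatter) from compound 2 to compound 4, at least 23-fold (1.37 log units) apart, beyond the scatter of two such steps. The outcome of the change therefore depends on the core in these four compounds, but compound 2 and compound 4 each stand at a limit of the assay rather than a number, so both new steps are bounds, and the set shows neither a rule for the wider series nor a reason for the reversal.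

Still open, on these data alone, is whether an unsubstituted benzylamino group or a longer alkyl chain on that nitrogen would follow compound 2 or compound 4 in this assay. Also open, as far as these compounds go, is how the isopropylamino to (4-fluorobenzyl)amino change would behave with a plain phenyl group in place of either ring group on the double-bonded chain carbon.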